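Swapping an Aryl Sulfonamide for a Methyl Sulfonamide

The compounds below may be only part of what the source reports. "The series", "measured", "known", "first", "only" and "open" are said of these compounds alone.

Compound 1 `CCOC(=O)c1cnc2ccc(-c3cnc(OC)c(NS(=O)(=O)c4ccc(F)cc4F)c3)cn12` is measured in a functional assay on A549 cells (Homo sapiens) for antiproliferative activity, read by sulforhodamine B assay, with a stated time of 72 h (a higher number here means a weaker inhibitor, a lower number a stronger inhibitor), where compound 1 gives 300 nM. Of the two numbers recorded, this is the lowest. Its closest neighbour is compound 2 `COc1ncc(-c2ccc3ncc(C(=O)O)n3c2)cc1NS(=O)(=O)c1ccc(F)cc1F`, which in this assay gives 1150 nM; the step of a 3.8-fold higher number from compound 1 to compound 2 (0.58 log units; beyond the scatter) arises from hydrogen in place of ethyl on an oxygen next to a carbonyl group. Compound 3 `CCOC(=O)c1cn2cc(-c3cnc(OC)c(NS(=O)(=O)c4ccc(F)cc4)c3)ccc2n1` reaches only (the limit of > 20000 nM in this assay, at which 1 of the 3 values shown sits), so for compound 3 in this assay the value > 20000 nM is a limit rather than a number.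

Compound 4 `CCOC(=O)c1cnc2ccc(-c3cnc(OC)c(NS(C)(=O)=O)c3)cn12` differs from compound 1 by methyl in place of 2,4-difluorophenyl on a sulfonyl sulfur whose other neighbours are a sulfonamide nitrogen. Within the data shown here, none of the measured steps touches this part of the molecule: the only recorded step concerns the ester, and compound 3 differs from compound 1 in more than one place, so its limit gives no direct guide. A direct reading is therefore not possible. Removing the whole aromatic ring is a large change, and compound 4 is expected to come out weaker, with the step of a 10-fold higher number from compound 1 to compound 4 (1.00 log units; beyond the scatter) as the estimated loss. For compound 4 the estimate in this assay is 3000 nM, within a range from 600 nM to 15000 nM.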

Compound 4, half-maximal inhibitory concentration: 230 nM
For compound 4 the middle estimate is 13-fold (1.12 log units) above the measured one; measured number outside the range, below it.
By their numbers in this assay, from the lowest: compounds 4 and 1 (each within the scatter of the next); then compound 2. At a limit, above all of these: compound 3.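

In this assay the step reads a 1.3-fold lower number from compound 1 to compound 4 (0.12 log units; within the scatter), so compound 1 and compound 4 cannot be told apart, even though a 2,4-difluorophenyl of 8 heavy atoms gives way to a methyl of 1 heavy atom. Among these compounds, this is the first view of the group on the sulfonyl sulfur, since the only earlier step concerned the ester, and for this pair the six-membered aromatic ring at this place is not needed to keep antiproliferative activity at this level. Nothing measured here explains why the activity holds up after so large a change.

From the compounds shown here alone, it remains open whether other small or medium groups on the sulfonyl sulfur, such as ethyl, cyclopropyl or a dimethylamine, would also leave the number within the scatter, or whether methyl is a special case. Going by these compounds, it is equally open whether a carboxylic acid in place of the ethyl ester on the core of compound 4 would give a step like a 3.8-fold higher number from compound 1 to compound 2 (0.58 log units; beyond the scatter), which would show whether the two parts of the molecule act independently.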